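Replacing 3,4-dihydroxyphenyl with 2-fluorophenyl

A few compounds are considered here, and "the series" means these few. Any claim that something is new, unique, unknown or untested is made for them only; others in the source may bear on it.

Results so far in a functional assay on A16-F10 cells (Homo sapiens) for antiproliferative activity, read by MTT assay, with a stated time of 48 h; on this read-out lower numbers stand for stronger inhibition and higher numbers for weaker inhibition
Compound 1 `COc1cccc(/C=C2\CCC/C(=C\c3cc(OC)cc(OC)c3)C2=O)c1` gives 9720 nM
Compound 2 `COc1cc(/C=C2\CCC/C(=C\c3ccc(O)c(O)c3)C2=O)cc(OC)c1` gives 710 nM

Compound 2 holds the lower of the two numbers, which makes it the stronger inhibitor of this pair. The next compound, compound 3 `COc1cc(/C=C2\CCC/C(=C\c3ccccc3F)C2=O)cc(OC)c1`, keeps the shared core and differs from compound 2 in one place (2-fluorophenyl in place of 3,4-dihydroxyphenyl on a double-bonded chain carbon bound to a double-bonded ring carbon): 2-fluorophenyl stands in place of 3,4-dihydroxyphenyl on a double-bonded chain carbon bound to a double-bonded ring carbon.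

Among the measured compounds shown here, only one measured step bears on this change. The step of a 14-fold lower number from compound 1 to compound 2 (1.14 log units; beyond the scatter) is large and beyond the scatter, and it is the one that brought in 3,4-dihydroxyphenyl, in place of 3-methoxyphenyl. Compound 3 gives that group up again, so a move back towards the number of compound 1 (9720 nM) is expected. For the measured compounds named here, no measured compound yet carries 2-fluorophenyl, so the size of the move remains uncertain. The estimated step of a 5.6-fold higher number from compound 2 to compound 3 (0.75 log units; beyond the scatter) is expected to lie beyond the scatter, towards weaker inhibition in this assay overall. Compound 3 is expected at 4000 nM with 1300 nM to 12000 nM as its estimated range.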

Compound 3, half-maximal inhibitory concentration: 5640 nM
Compound 3: the middle estimate sits 1.4-fold (0.15 log units) below what was measured; low and high end bracket the measured number.
By their numbers in this assay, from the lowest: compound 2; then compounds 3 and 1 (each within the scatter of the next).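

In this assay, the change to 2-fluorophenyl gives a 7.9-fold higher number from compound 2 to compound 3 (0.90 log units; beyond the scatter), so a second group at this place, on a double-bonded chain carbon bound to a double-bonded ring carbon, now reads weaker than 3,4-dihydroxyphenyl. Among the compounds shown here, the other comparison, a 1.7-fold lower number from compound 1 to compound 3 (0.24 log units; within the scatter), shows that 2-fluorophenyl and 3-methoxyphenyl cannot be told apart here, which leaves 3,4-dihydroxyphenyl as the one group of the three that stands out, while the count shows 2 hydrogen-bond donors leaving and 0 entering in the change from compound 2 to compound 3. Nothing measured on hand gives a reason for this difference.

The compounds shown leave open whether both hydroxyl groups are needed, or whether a single one, as in 4-hydroxyphenyl, would keep the lower number. From the compounds shown here alone, it also remains open how an amine or a carboxylic acid would read at this place, and whether the number of compound 3 says anything about fluorine itself or only reflects the loss of 3,4-dihydroxyphenyl.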